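Carbamoyl in place of methoxy: expectation for compound 4

This account rests on a few compounds, and the source may have more. Where it says the series, first, only, none or still open, it means among the compounds named here.

Compound 2 `COc1cc(N2C[C@@H]3CCNC[C@@H]32)cnc1Br` gives the highest number of the three measured in a functional assay on HEK293 cells for agonist activity at Neuronal acetylcholine receptor; alpha3/beta4 (Homo sapiens), read by FLIPR (on this read-out higher numbers stand for an effect only at larger amounts of compound and lower numbers for an effect already at smaller amounts), namely 2980 nM. Its nearest neighbour is compound 1 `Brc1cncc(N2CC[C@@H]3CN[C@@H]3C2)c1`, which gives 950 nM, and the furthest is compound 3 `COc1cc(N2C[C@H]3CCNC[C@H]32)cnc1Br`, which gives 202 nM. Within the data shown here, the one measured step, a 15-fold lower number from compound 2 to compound 3 (1.17 log units; beyond the scatter), rests on the fact that compounds 2 and 3 differ only in the configuration as drawn and so carries no information about exchanging a substituent on the aromatic ring. Compound 4 `NC(=O)c1cc(N2C[C@@H]3CCNC[C@@H]32)cnc1Br` carries carbamoyl in place of methoxy on an aromatic carbon. Among the measured compounds shown here, no measured pair swaps a group at this place, so no direction can be read from the data. The expected step is a 1.0-fold higher number from compound 2 to compound 4 (0.00 log units; within the scatter), not beyond the scatter. Compound 4 is therefore estimated at 3000 nM in this assay, with a range from 700 nM to 13000 nM.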

Compound 4, half-maximal effective concentration: 23300 nM
Compound 4: middle estimate off by 7.8-fold (0.89 log units), on the low side; measured number outside the range, above it.
By their numbers in this assay, from the lowest: compound 3; then compound 1; then compound 2; then compound 4.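

In this assay, among these compounds, the aromatic carbon ortho to a bromo group and two atoms from the ring nitrogen responds to a change of substituent: carbamoyl in place of methoxy gives a 7.8-fold higher number from compound 2 to compound 4 (0.89 log units; beyond the scatter) and is the only measured exchange of a group at this place. The earlier step concerned configuration alone. Nothing available bears on the reason for this step.

Open, going by these compounds, is whether the same exchange on the configuration of compound 3 gives a step of similar size. Also open, on these data alone, is how an amine, a carboxylic acid or a methyl ester would read at this place.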